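The source may hold more compounds than are shown below. What is called first, only, known or untested is meant among the compounds shown, and "the series" means these compounds.

Measured in an ADME assay on HepG2 cells (Homo sapiens) for cytotoxicity, read by MTT assay, with a stated time of 72 h; on this read-out higher numbers stand for lower toxicity in this test and lower numbers for higher toxicity in this test:
- compound 1 `CS(=O)(=O)Cc1nc2c(Sc3ccc(Cl)cc3)cc(Cl)cn2c1[N+](=O)[O-]`: > 31200 nM (a limit)
- compound 2 `CS(=O)(=O)Cc1nc2c(Br)cc(Cl)cn2c1[N+](=O)[O-]`: 45000 nM
- compound 3 `Cc1nc2c(Br)cc(Cl)cn2c1[N+](=O)[O-]`: > 125000 nM (a limit)

Compound 1 has no exact number in this assay, only the limit > 31200 nM. Compound 4 `O=[N+]([O-])c1c(CS(=O)(=O)c2cccnc2)nc2c(Sc3ccc(Cl)cc3)cc(Cl)cn12` keeps the core of compound 1 and carries pyridin-3-yl in place of methyl on a sulfonyl sulfur.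

Within the data shown here, no measured step makes this same swap, so the evidence is indirect. The first step, a step that the limit leaves unreadable from compound 1 to compound 2, lies at another place in the molecule. The second, an at least 2.7-fold higher number from compound 2 to compound 3 (0.44 log units; beyond the scatter), removes the whole methylsulfonyl group, whereas compound 4 keeps its sulfonyl. The nearest exact number for a compound with a sulfonyl group is compound 2 at 45000 nM.

No clear step in either direction is therefore expected in this assay. The expected change is an at least 1.0-fold lower number from compound 1 to compound 4 (0.01 log units; that floor lies within the scatter). Compound 4 is estimated at 30000 nM, with an expected range from 10000 nM to 80000 nM.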

Compound 4, half-maximal cytotoxic concentration: > 31200 nM
Compound 4: no number, only a limit (the forecaster's own chance of this, stated with the estimate: 50%); middle value at least 1.0-fold (0.01 log units) from the limit.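

In this assay compound 4 gives > 31200 nM, which is a limit and not a number. Compound 1 also has only a limit, and no step from compound 1 to compound 4 can be read: the limit of > 31200 nM in this assay, at which 2 of the 4 values shown sit.

The compounds shown leave open how far pyridin-3-yl in place of methyl on a sulfonyl sulfur moves the number, if it moves it at all.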